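This account rests on a few compounds, and the source may have more. Where it says the series, first, only, none or still open, it means among the compounds named here.

Compound 1 `Nc1cccc2c(-c3cccc(NC(=O)c4ccc5c(c4)OCCO5)c3)ccnc12` gives > 20000 nM in a functional assay on SK-MEL-2 cells (Homo sapiens) for antiproliferative activity, read by sulforhodamine B assay, with a stated time of 48 h; a lower number here means a stronger inhibitor, a higher number a weaker inhibitor; compound 2 `CC(=O)Nc1cccc2c(-c3cccc(NC(=O)c4ccc5c(c4)OCCO5)c3)ccnc12` gives > 20000 nM; compound 3 `Nc1cccc2c(-c3cccc(NC(=O)Nc4cc(C(F)(F)F)cc(C(F)(F)F)c4)c3)ccnc12` gives 1400 nM.

The values of compound 1 and compound 2 are limits of this assay, not numbers. Among the measured compounds shown here, compound 3 is the only one with a measured number. Compound 1 and compound 2 differ by one change, (acetyl in place of hydrogen on a nitrogen on an aromatic ring), and the step that the two limits leave unreadable from compound 1 to compound 2 cannot be read, because the limit of > 20000 nM in this assay, at which 2 of the 3 values shown sit, holds both ends. Compound 4 `CC(=O)Nc1cccc2c(-c3cccc(NC(=O)Nc4cc(C(F)(F)F)cc(C(F)(F)F)c4)c3)ccnc12` is not yet measured; it differs from compound 3 by the same change, (acetyl in place of hydrogen on a nitrogen on an aromatic ring), at the same kind of place. How the core of compound 3 differs from that of compound 1 is not broken down here. With the earlier step unreadable, the step from compound 3 to compound 4 is expected to be small, a 1.4-fold higher number from compound 3 to compound 4 (0.15 log units; within the scatter). Compound 4 is estimated at 2000 nM, within 700 nM to 8000 nM.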

Compound 4, half-maximal inhibitory concentration: 14400 nM
Compound 4: middle estimate off by 7.2-fold (0.86 log units), on the low side; the whole stated range lies below it.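

In this assay, acetyl in place of hydrogen on a nitrogen on an aromatic ring gives a 10-fold higher number from compound 3 to compound 4 (1.01 log units; beyond the scatter), so on the core of compound 3 this change of amino to acetamido clearly weakens the compound. The same change from compound 1 to compound 2 cannot be read, because both values are limits rather than numbers: the limit of > 20000 nM in this assay, at which 2 of the 4 values shown sit. This is therefore one readable case on one core, and it neither confirms nor rules out a similar loss on the core of compound 1.

The compounds shown leave open whether the loss is specific to acetyl or would follow other groups on that nitrogen. A simple methyl group or a longer propanoyl chain does not appear among them.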